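A few compounds are considered here, and "the series" means these few. Any claim that something is new, unique, unknown or untested is made for them only; others in the source may bear on it.

Series notes, rat aorta.

In a functional assay (aorta) with Rattus norvegicus as the target (on this read-out lower numbers stand for an effect already at smaller amounts and higher numbers for an effect only at larger amounts of compound), compound 1 `Cc1ccc(NC(=O)NC2CC(C)(C)Oc3ccc(Cl)cc32)cc1` reaches only the limit > 30000 nM and no number. Compound 2 `Cc1ccc(NC(=O)NC2CC(C)(C)Oc3ccc(Br)cc32)cc1` likewise sits at the limit > 30000 nM in this assay. For compound 3 `CC1(C)CC(NC(=O)Nc2ccccc2Cl)c2cc(Cl)ccc2O1` this assay gives the limit > 300000 nM, again not a number.

The step from compound 1 to compound 2 is bromo in place of chloro on an aromatic carbon; its size, a step that the two limits leave unreadable from compound 1 to compound 2, cannot be read because the limit of > 30000 nM in this assay, at which 2 of the 3 values shown sit, caps both values. The cores of compound 1 and compound 3 differ by 2-chlorophenyl in place of 4-methylphenyl on an amide-type nitrogen; the step that the two limits leave unreadable from compound 1 to compound 3 is equally unreadable, as compound 3 is held by the limit of > 300000 nM in this assay, at which 1 of the 3 values shown sits, and compound 1 by the limit of > 30000 nM in this assay, at which 2 of the 3 values shown sit.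

Compound 4 `CC1(C)CC(NC(=O)Nc2ccccc2Cl)c2cc(Br)ccc2O1` is not yet measured in this assay. Its relation to compound 3 is bromo in place of chloro on an aromatic carbon, the same change made from compound 1 to compound 2, at the same place. The expected step of a number no higher from compound 3 to compound 4 (the limit leaves the size open) is estimated as near nil, since compound 1 and compound 2 both stay at the limit of > 30000 nM in this assay, at which 2 of the 3 values shown sit, and compound 3 at the limit of > 300000 nM in this assay, at which 1 of the 3 values shown sits. Compound 4 is therefore expected to give about 300000 nM in this assay, most likely reported as a limit, between 30000 nM and 3000000 nM.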

Compound 4, half-maximal effective concentration: > 30000 nM
Compound 4 gave a limit, no number (the forecaster's own chance of this, stated with the estimate: 85%); the middle value does not contradict the limit.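

In this assay compound 4 gives > 30000 nM, a limit and not a number. Its steps from compound 3 and from compound 2 therefore cannot be read: the limit of > 30000 nM in this assay, at which 3 of the 4 values shown sit.

The compounds shown leave open whether bromo in place of chloro, or 2-chlorophenyl in place of 4-methylphenyl, changes the effect at all.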